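Sulfoxide in Place of Methylsulfanyl on Two Related Cores

A few compounds are considered here, and "the series" means these few. Any claim that something is new, unique, unknown or untested is made for them only; others in the source may bear on it.

Measured so far:
compound 1, `CSc1ccc(CSc2nc(-c3ccc(Cl)cc3)c(-c3ccncc3)[nH]2)cc1`: 2200 nM
compound 2, `C[S+]([O-])c1ccc(CSc2nc(-c3ccc(Cl)cc3)c(-c3ccncc3)[nH]2)cc1`: 320 nM
compound 3, `CSc1ccc(O)c(CSc2nc(-c3ccc(F)cc3)c(-c3ccncc3)[nH]2)c1`: 740 nM

Of the compounds shown here, three have been tested in a functional assay (Homo sapiens) for inhibition; a higher number here means a weaker inhibitor, a lower number a stronger inhibitor. Compound 1 gives 2200 nM, and compound 2 gives 320 nM. The two differ only by a group of 3 heavy atoms (1 carbon, 1 oxygen, 1 sulfur; no ring) in place of a group of 2 heavy atoms (1 carbon, 1 sulfur; no ring), on an aromatic carbon, and this change made the step of a 6.9-fold lower number from compound 1 to compound 2 (0.84 log units; beyond the scatter), a drop in the number that lies beyond the usual scatter. Compound 3 gives 740 nM in this assay, standing between the other two; the difference between the core of compound 1 and the core of compound 3 is not broken down here, since they differ in more than one place.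

Compound 4, `C[S+]([O-])c1ccc(O)c(CSc2nc(-c3ccc(F)cc3)c(-c3ccncc3)[nH]2)c1`, has not yet been measured. It differs from compound 3 by a group of 3 heavy atoms (1 carbon, 1 oxygen, 1 sulfur; no ring) in place of a group of 2 heavy atoms (1 carbon, 1 sulfur; no ring), on an aromatic carbon. Going by the values given here, this is the same kind of change as the one from compound 1 to compound 2, but not the same: in compound 1 the place is para to a large group, while in compound 3 it is meta to a large group and para to a hydroxy group. Among the compounds with values here, only one example of this change is known, so the surroundings of the place may alter its effect.

Within the data shown here, for compound 4 a step of a 3.7-fold lower number from compound 3 to compound 4 (0.57 log units; beyond the scatter) is expected, resting on the single earlier step of a 6.9-fold lower number from compound 1 to compound 2 (0.84 log units; beyond the scatter) and allowing for the changed surroundings. Compound 4 is therefore estimated at 200 nM in this assay, most likely between 80 nM and 500 nM.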

Compound 4, half-maximal inhibitory concentration: 1000 nM
Compound 4: the middle estimate sits 5.0-fold (0.70 log units) below what was measured; measured number above the stated range.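

In this assay, going by these compounds alone, replacing methylsulfanyl with the sulfoxide on the core of compound 3 gives a 1.4-fold higher number from compound 3 to compound 4 (0.13 log units; within the scatter), so on this core the swap produces no step that can be told apart from the usual scatter of repeated measurements. The gain in the earlier pair therefore does not carry over unchanged from one core to the other, and the two results really do differ: the same change on two cores in this assay, a 6.9-fold lower number (0.84 log units; beyond the scatter) from compound 1 to compound 2 and a 1.4-fold higher number (0.13 log units; within the scatter) from compound 3 to compound 4, 9.3-fold (0.97 log units) apart, beyond the scatter of two such steps

Compound 1 and compound 3 differ in more than one place, so these two pairs do not show whether the gap goes with the hydroxy group, with fluorine in place of chlorine, or with both together, and two pairs are too few to support a general rule for this change.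

The same swap on a core carrying only one of those two differences would help to separate them. The compounds shown also leave open how a methylsulfonyl group, an amine or a carboxylic acid on the same aromatic carbon would read in this assay, on either core.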